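Carbamate selenium compounds: cell growth inhibition working notes

This account rests on a few compounds, and the source may have more. Where it says the series, first, only, none or still open, it means among the compounds named here.

Measured so far in an ADME assay on BEAS-2B cells (Homo sapiens) for cytotoxicity, read by MTT assay, with a stated time of 72 h; a lower number here means a stronger inhibitor of growth, a higher number a weaker inhibitor of growth:
compound 1 `N#C[Se]c1ccc(NC(=O)OCc2ccccc2)cc1` gives 34400 nM
compound 2 `CCOC(=O)Nc1ccc([Se][Se]c2ccc(NC(=O)OCC)cc2)cc1` gives 44000 nM

Compound 1 has the lowest of the two numbers, but compound 2 stands within the scatter of it, so the two values show no order between them and neither compound can be called the stronger inhibitor of growth.

Compound 3 `CCCCCCOC(=O)Nc1ccc([Se]C#N)cc1` is the next compound to be measured in this assay. Its difference from compound 1 is pentyl in place of phenyl on a saturated chain carbon bound to an oxygen next to a carbonyl group. The change sits on a saturated chain carbon bound to an oxygen next to a carbonyl group, and the rest of compound 1 is kept. Among the measured compounds shown here, no pair of measured compounds differs in one place, so nothing measured tells the size of this kind of change, and the two measured values themselves lie within the scatter of each other.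

Expectation: no step beyond the scatter, so a 1.1-fold lower number from compound 1 to compound 3 (0.06 log units; within the scatter) is estimated to be small. The estimate for compound 3 is 30000 nM, with a range from 12000 nM to 80000 nM.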

Compound 3, concentration for total growth inhibition: 35900 nM
Beside the measured number, compound 3's estimate is 1.2-fold (0.08 log units) below it; the range from low to high includes it.
By their numbers in this assay, from the lowest: compounds 1, 3 and 2 (each within the scatter of the next).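

In this assay, pentyl in place of phenyl on a saturated chain carbon bound to an oxygen next to a carbonyl group gives a 1.0-fold higher number from compound 1 to compound 3 (0.02 log units; within the scatter). Among the compounds shown here, this is the first one-place step, and it shows that at this position, a six-membered aromatic ring of carbon only and a chain with no ring give values with no order between them, with the rest of compound 1 kept. Nothing available bears on why these two values stand within the scatter of each other.

As far as these compounds go, this single pair sets no pattern for the position, so it remains open whether a longer chain, an amine or a carboxylic acid at this place would also stay within the scatter of compound 1. From the compounds shown here alone, compound 2 differs from compound 1 and compound 3 in more than one place, so the contribution of the nitrile on selenium to the values in this assay also remains open.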